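Adding a bromine to the second phenyl of compound 2

This account rests on a few compounds, and the source may have more. Where it says the series, first, only, none or still open, it means among the compounds named here.

Three compounds share one core and differ only in the aryl group attached to the carbonyl. Compound 1 `COc1cccc(C(=O)Nc2cc(-c3ccccc3)nn2-c2ccccc2)c1` gives 102 nM in a functional assay on cells for positive allosteric modulation of metabotropic glutamate receptor 5 (Rattus norvegicus), read by calcium flux; on this read-out lower numbers stand for an effect already at smaller amounts and higher numbers for an effect only at larger amounts of compound. Compound 2 `O=C(Nc1cc(-c2ccccc2)nn1-c1ccccc1)c1cccc([N+](=O)[O-])c1` gives 39 nM in this assay, and compound 3 `O=C(Nc1cc(-c2ccccc2)nn1-c1ccccc1)c1ccc([N+](=O)[O-])cc1` gives 10.7 nM in this assay. Compound 2 thus stands second highest of the three numbers: the step of a 2.6-fold lower number from compound 1 to compound 2 (0.42 log units; beyond the scatter) is modest, and the step of a 3.6-fold lower number from compound 2 to compound 3 (0.56 log units; beyond the scatter) is modest in the same direction, while a 9.5-fold lower number from compound 1 to compound 3 (0.98 log units; beyond the scatter) is the largest step seen.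

Compound 4 `O=C(Nc1cc(-c2ccccc2)nn1-c1ccccc1Br)c1cccc([N+](=O)[O-])c1` is not yet measured. It differs from compound 2 in one place: bromo in place of hydrogen on an aromatic carbon, on an aromatic carbon of a six-membered aromatic ring of carbon only, ortho to a large group; the same difference, cut one bond further out, reads phenyl to 2-bromophenyl. Within the data shown here, none of the measured steps touches this ring; all three change the group on the carbonyl carbon. Among the measured compounds shown here, no measured step therefore bears on this change, and the expectation must be wide. The most plausible expectation is a step of a 1.0-fold higher number from compound 2 to compound 4 (0.01 log units; within the scatter) that stays within the scatter. On that basis compound 4 is estimated at 40 nM in this assay, with a range from 10 nM to 160 nM.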

Compound 4, half-maximal effective concentration: 68 nM
Estimate against measurement, compound 4: 1.7-fold (0.23 log units) below, and the stated range covers the measured number.
By their numbers in this assay, from the lowest: compound 3; then compounds 2, 4 and 1 (each within the scatter of the next, the first and the last beyond it).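

Among these compounds, compound 4 is the first compound here changed on a ring other than the aryl group on the carbonyl, and in this assay the move from phenyl to 2-bromophenyl gives a 1.7-fold higher number from compound 2 to compound 4 (0.24 log units; within the scatter). The three earlier steps, all made on the carbonyl side, each lay beyond the scatter, whereas this one lies within it, so this place, ortho to a large group, can carry a bromo group with no clear change in the number for this pair. The data offer no measured property that could explain this result.

Among the compounds shown here, the single pair also leaves open whether the same bromo change would stay within the scatter on the 4-nitrophenyl amide, compound 3, which has the lowest number of the set. It cannot show whether the room for change at this place extends to other groups, such as a methyl, an amine or a carboxylic acid, or whether those would move the number as far as the changes on the carbonyl side did.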